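Phenyl in place of methyl: one change, seen twice

This account rests on a few compounds, and the source may have more. Where it says the series, first, only, none or still open, it means among the compounds named here.

Measured in an assay on mitochondria for inhibition of Amine oxidase [flavin-containing] A (Bos taurus); on this read-out higher numbers stand for weaker inhibition and lower numbers for stronger inhibition:
compound 1, `Cc1csc(N/N=C/c2ccccc2)n1`, gives 7.24 nM
compound 2, `C(=N/Nc1nc(-c2ccccc2)cs1)\c1ccccc1`, gives 1200 nM
compound 3, `Cc1csc(N/N=C/c2ccc(Cl)cc2Cl)n1`, gives 12 nM

Compound 4, `Clc1ccc(/C=N/Nc2nc(-c3ccccc3)cs2)c(Cl)c1`, has not been measured. It differs from compound 3 by phenyl in place of methyl on an aromatic carbon. The same kind of change separates compound 1 from compound 2: phenyl in place of methyl on an aromatic carbon. The two places differ only in how the group two ring bonds away is described, a large group in one case and a group of 9 heavy atoms in the other. How the cores of compound 1 and compound 3 differ is not broken down here; their numbers in this assay lie within the scatter of each other, while compound 2 stands well apart from both.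

The measured step for this change is a 170-fold higher number from compound 1 to compound 2 (2.22 log units; beyond the scatter). Since the change and its surroundings are alike, a step of similar size is expected from compound 3 to compound 4: a 170-fold higher number from compound 3 to compound 4 (2.22 log units; beyond the scatter). Compound 4 is therefore estimated at 2000 nM, with a range from 400 nM to 10000 nM.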

Compound 4, inhibition constant: 93.3 nM
Compound 4: the middle estimate sits 21-fold (1.33 log units) above what was measured; measured number below the stated range.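

In this assay, the new step is a 7.8-fold higher number from compound 3 to compound 4 (0.89 log units; beyond the scatter), so the change again goes with weaker inhibition, but by much less than on the core of compound 1. Set side by side, the two steps agree in direction and not in size: the same change on two cores in this assay, a 170-fold higher number (2.22 log units; beyond the scatter) from compound 1 to compound 2 and a 7.8-fold higher number (0.89 log units; beyond the scatter) from compound 3 to compound 4, 21-fold (1.33 log units) apart, beyond the scatter of two such steps This shows that, on these two cores, the direction of the change carried over while its size did not, so a step measured on one core is a poor guide to its size on the other; with only two pairs, it does not show which difference in the cores accounts for the gap, or how the step would run on any further core.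

The compounds shown leave open how a smaller or different group at this place on the ring, such as an ethyl, an amine or a carboxylic acid, would compare with methyl and phenyl. They also leave open whether the same steps would appear in any read-out other than this assay.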